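A Second Methoxy Group on a Sulfonamide Analog

The source may hold more compounds than are shown below. What is called first, only, known or untested is meant among the compounds shown, and "the series" means these compounds.

Of the compounds shown here, three built on one shared core have been tested in a functional assay on KB cells (Homo sapiens) for antiproliferative activity, read by MTT assay, with a stated time of 72 h; on this read-out lower numbers stand for stronger inhibition and higher numbers for weaker inhibition. Compound 1 `CN(C(=O)c1ccccc1)c1ccc2[nH]c(-c3n[nH]c4ccccc34)cc2n1` gives 8580 nM in this assay. Compound 2 `COc1ccc(C(=O)N(C)c2ccc3[nH]c(-c4n[nH]c5ccccc45)cc3n2)cc1` differs from it only by methoxy in place of hydrogen on an aromatic carbon, and in this assay compound 2 gives 12900 nM. The resulting step is a 1.5-fold higher number from compound 1 to compound 2 (0.18 log units; within the scatter). Compound 3 `COc1ccc(S(=O)(=O)N(C)c2ccc3[nH]c(-c4n[nH]c5ccccc45)cc3n2)cc1` gives 22100 nM in this assay; the difference between the core of compound 1 and the core of compound 3 is not broken down here. The number for compound 3 lies within the scatter of the number for compound 2, while its gap to compound 1 is beyond the scatter.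

Compound 4 `COc1ccc(S(=O)(=O)N(C)c2ccc3[nH]c(-c4n[nH]c5ccccc45)cc3n2)cc1OC` has not been measured. It differs from compound 3 by methoxy in place of hydrogen on an aromatic carbon. Among the compounds with values here, this is the same kind of change as the one from compound 1 to compound 2, but not the same: in compound 2 the entering group sits para to a large group, whereas in compound 4 it sits ortho to a methoxy group and meta to a large group. Within the data shown here, only one measured instance of this kind of change exists here, namely a 1.5-fold higher number from compound 1 to compound 2 (0.18 log units; within the scatter), and it stayed within the scatter. On that basis the step expected from compound 3 to compound 4 is a 1.3-fold higher number from compound 3 to compound 4 (0.10 log units; within the scatter), again small. Compound 4 is therefore estimated to give 28000 nM in this assay, with an expected range from 12000 nM to 65000 nM.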

Compound 4, half-maximal inhibitory concentration: 10100 nM
Compound 4: the middle estimate sits 2.8-fold (0.44 log units) above what was measured; measured number outside the range, below it.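

In this assay, the methoxy group entering the ring of compound 3 gives a 2.2-fold lower number from compound 3 to compound 4 (0.34 log units; beyond the scatter), a modest change that runs the opposite way to the earlier step, so this change did not carry over unchanged from one core to the other: the same change on two cores in this assay, a 1.5-fold higher number (0.18 log units; within the scatter) from compound 1 to compound 2 and a 2.2-fold lower number (0.34 log units; beyond the scatter) from compound 3 to compound 4, 3.3-fold (0.52 log units) apart, beyond the scatter of two such steps

This shows that the effect of adding a methoxy group in this series cannot simply be copied from one compound pair to another, even though the same atoms enter each time. It does not show that the core alone sets the outcome, since the two pairs also differ in the ring being changed: in compound 4 the new group sits ortho to a methoxy group and meta to a large group, and the ring of compound 1 carries no methoxy group at all. Within the data shown here, with only one pair on each side, neither the core nor the place of the new group can be singled out, and no general rule follows.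

The compounds shown leave open what a 3,4-dimethoxyphenyl group would do on the core of compound 1, a comparison that would help separate the core from the position. They also leave open whether a hydroxyl group, an amine or a longer chain such as ethoxy in the same place on compound 3 would shift the number in the same direction.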